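The source may report more compounds than this note shows. Statements on the series, on what has been measured and on what is new or still open speak of the compounds shown alone.

Measured compounds: compound 1 `C=CC1=C(C(=O)NC(C)(C)C)C(c2ccc(OC)cc2)OC1` gives > 100000 nM; compound 2 `C=CC1=C(C(=O)NC2CCCCC2)C(c2ccc(OC)cc2)OC1` gives 24800 nM; compound 3 `C=CC1=C(C(=O)Nc2ccc(C)cc2)C(c2ccc(OC)cc2)OC1` gives > 100000 nM.

In a functional assay on HeLa cells (Homo sapiens) for cytotoxicity, read by MTT assay, with a stated time of 24 h (on this read-out higher numbers stand for weaker inhibition and lower numbers for stronger inhibition), compound 3 stands at a limit, not a number. Compound 1 also stands at a limit in this assay. Two of the three values therefore sit at the limit of > 100000 nM in this assay, at which 2 of the 3 values shown sit, and only compound 2 gives a number. Among the compounds with values here, the step of an at least 4.0-fold higher number from compound 2 to compound 3 (0.60 log units; beyond the scatter) is the one readable step ending at compound 3, while a step that the two limits leave unreadable from compound 1 to compound 3 cannot be sized, and an at least 4.0-fold lower number from compound 1 to compound 2 (0.60 log units; beyond the scatter) shows that the cyclohexyl compound is the one with the lower number among the three.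

Compound 4 `C=CC1=C(C(=O)NCc2ccccc2)C(c2ccc(OC)cc2)OC1` differs from compound 3 by benzyl in place of 4-methylphenyl on an amide-type nitrogen. Within the data shown here, no measured pair shows this benzyl-for-aryl exchange directly; the nearest evidence is that the cyclohexyl substituent of compound 2 gave a number where the tert-butyl of compound 1 and the 4-methylphenyl of compound 3 gave only limits. The step from compound 3 to compound 4 is therefore expected to be an at least 2.0-fold lower number from compound 3 to compound 4 (0.30 log units; that floor lies within the scatter), with a real chance that the assay again reports only a limit. Compound 4 is estimated at 50000 nM, within 15000 nM to 200000 nM.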

Compound 4, half-maximal inhibitory concentration: > 100000 nM
Compound 4: no number, only a limit; the forecaster's own chance of this, stated with the estimate: 50%; middle value at least 2.0-fold (0.30 log units) away from the limit.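

In this assay compound 4 gives > 100000 nM, which is a limit and not a number, so rejoining the same atoms as benzyl in place of 4-methylphenyl on the amide-type nitrogen does not bring a measurable value. Replacing cyclohexyl with benzyl gives an at least 4.0-fold higher number from compound 2 to compound 4 (0.60 log units; beyond the scatter), so an aromatic ring held one carbon away from this nitrogen does not match the cyclohexyl group. The steps from compound 1 and from compound 3 to compound 4 cannot be read, and cyclohexyl remains the only group here with a number: the limit of > 100000 nM in this assay, at which 3 of the 4 values shown sit.

On these data alone, how far compound 1, compound 3 and compound 4 lie past that limit stays open, so they cannot be ordered. Also open, as far as these compounds go, is how a cyclopentyl group, a longer alkyl chain or an amine-bearing chain on this nitrogen would compare with the cyclohexyl group of compound 2.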